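A few compounds are considered here, and "the series" means these few. Any claim that something is new, unique, unknown or untested is made for them only; others in the source may bear on it.

Compound 3, `O=[N+]([O-])c1cn2c(n1)OC[C@@H](OCc1cnn(-c3ccc(C(F)(F)F)cc3)c1)C2`, is one of three close relatives tested in an ADME assay on Vero cells (Chlorocebus sabaeus) for cytotoxicity, with a stated time of 72 h; a higher number here means a weaker inhibitor, a lower number a stronger inhibitor. In this assay compound 3 reaches only the limit of > 128000 nM, a boundary of the measurement rather than a number. Compound 1, `N#Cc1ccc(-c2ccc(CO[C@@H]3COc4nc([N+](=O)[O-])cn4C3)s2)cc1`, likewise stops at the limit of > 128000 nM. Compound 2, `O=[N+]([O-])c1cn2c(n1)OC[C@@H](OCc1csc(-c3ccc(C(F)(F)F)cc3)n1)C2`, also sits at the limit of > 128000 nM. So all three share (the limit of > 128000 nM in this assay, at which 3 of the 3 values shown sit), and no compound stands apart from another here. Compound 4, `O=[N+]([O-])c1cn2c(n1)OC[C@@H](OCc1cnn(-c3ccc(F)cc3)c1)C2`, differs from compound 3 by fluoro in place of trifluoromethyl on an aromatic carbon. With every relative at the limit, compound 4 is expected to stay at the limit as well, so the step that the limit leaves unreadable from compound 3 to compound 4 is estimated to lie within the scatter. Compound 4 is thus estimated at 150000 nM, between 64000 nM and 400000 nM.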

Compound 4, half-maximal inhibitory concentration: > 128000 nM
Compound 4 ended at the assay's limit; the forecaster's own chance of this, stated with the estimate: 85%; the middle value lies beyond the limit too.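

Compound 3 and compound 4 both stop at a limit rather than a number in this assay, so the change from trifluoromethyl to fluoro cannot be read. The compounds shown leave open how far beyond that limit each one's true value lies.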